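From compound 1 to compound 3: a nitrile enters

The source may hold more compounds than are shown below. What is called first, only, known or untested is meant among the compounds shown, and "the series" means these compounds.

Values so far in an ADME assay on J774.A1 cells (Mus musculus) for cytotoxicity, read by MTT assay (on this read-out higher numbers stand for weaker inhibition and lower numbers for stronger inhibition), are these.
- Compound 1 `O=C1NC(=S)N/C1=C\c1cn(CCCCCOc2ccccc2)c2ccccc12` gives > 100 ug/mL as a limit of the assay
- Compound 2 `N#Cc1ccc(OCCCCCCn2cc(/C=C3\NC(=S)NC3=O)c3ccccc32)cc1` gives 2.3 ug/mL as a number

Compound 1 has only a limit and no number, and it stands at the limit of > 100 ug/mL in this assay, at which 1 of the 2 values shown sits, on the scale.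

Compound 3 `N#Cc1ccc(OCCCCn2cc(/C=C3\NC(=S)NC3=O)c3ccccc32)cc1` has not yet been measured. It carries 4-cyanophenoxy in place of phenoxymethyl on a saturated chain carbon, four bonds along the chain from an aromatic nitrogen, and the full count of that change is 4-cyanophenoxy in place of phenoxymethyl on a saturated chain carbon, four bonds along the chain from an aromatic nitrogen in this comparison.

Going by the values given here, one measured step bears on it. That is an at least 43-fold lower number from compound 1 to compound 2 (1.63 log units; beyond the scatter), a large step beyond the scatter that starts from a limit, with (4-cyanophenoxy)methyl in place of phenoxy on a saturated chain carbon, five bonds along the chain from an aromatic nitrogen. The same cyano-bearing ring enters in both changes, but at a different place along the chain, so the earlier step is only a rough guide. A large step to a lower number is therefore expected in this assay here too, perhaps a smaller one. The expected step is an at least 10-fold lower number from compound 1 to compound 3 (1.00 log units; beyond the scatter) in this estimate. Compound 3 is estimated at 10 ug/mL, with an expected range from 2.5 ug/mL to 60 ug/mL as the measurement is awaited.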

Compound 3, half-maximal inhibitory concentration: > 100 ug/mL
Compound 3: a limit, no number (the forecaster's own chance of this, stated with the estimate: 20%); middle value at least 10-fold (1.00 log units) from the limit.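

No step can be read between compound 1 and compound 3, because both stand at a limit of the assay and neither has a number: the limit of > 100 ug/mL in this assay, at which 2 of the 3 values shown sit.

The compounds shown leave open whether, in this assay, 4-cyanophenoxy in place of phenoxymethyl on a saturated chain carbon, four bonds along the chain from an aromatic nitrogen, changes the result at all.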